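Bromo to methoxy in a series known only by limits

The compounds below may be only part of what the source reports. "The series", "measured", "known", "first", "only" and "open" are said of these compounds alone.

Of the compounds shown here, three have been read so far, and none has given a number. In an ADME assay on Vero cells (Chlorocebus sabaeus) for cytotoxicity, read by neutral red uptake (on this read-out higher numbers stand for lower toxicity in this test and lower numbers for higher toxicity in this test), compound 1 (`CC(=O)C(=C/C=C/c1ccc(Br)cc1)C(C)=O`) reports > 16.2 uM as a limit of the assay. Compound 2 (`CC1(C)CC(=O)C(=CC=C(c2ccccc2)c2ccccc2)C(=O)C1`) reports > 14.4 uM as a limit in this assay as well. Compound 3 (`CC1(C)CC(=O)C(=C/C=C/c2ccc(Br)cc2)C(=O)C1`) reports > 14.3 uM as a limit in this assay too, so it stands with the other two, and no order can be drawn among the three.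

The next compound to be read is compound 4 (`COc1ccc(/C=C/C=C2C(=O)CC(C)(C)CC2=O)cc1`), which keeps the rest of compound 3 and carries methoxy in place of bromo on an aromatic carbon, para to a large group (methoxy in place of bromo on an aromatic carbon). Among the compounds with values here, no measured pair differs in one place, so the data give no size for such a change. The expectation is therefore no step beyond the usual scatter, in either direction, and another limit is the likeliest report. The expected step that the limit leaves unreadable from compound 3 to compound 4 is estimated to stay within that scatter. For compound 4 the estimated value is 20 uM on this read-out, with the expected range running from 7 uM to 60 uM in this assay once it is measured.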

Compound 4, half-maximal toxic concentration: > 16.7 uM
Compound 4 ended at the assay's limit; the forecaster's own chance of this, stated with the estimate: 70%; the middle value does not contradict the limit.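

Compound 3 and compound 4 both report only limits in this assay, so no step can be read between them and the exchange of bromo for methoxy has no size here. All four compounds shown stand as limits, which leaves open where any true half-maximal toxic concentration lies and whether this exchange shifts it at all.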